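The source may report more compounds than this note shows. Statements on the series, on what has been measured and on what is new or still open speak of the compounds shown alone.

Working notes on a short series sharing the core of compound 1 `O=C(O)c1ccccc1-c1ccc(CCc2ncc(CCC3CCCCC3)[nH]2)cc1`, which in an in vitro functional assay on cells for agonist activity at Bombesin receptor subtype-3 (Mus musculus), read by luminescence and calcium flux (on this read-out lower numbers stand for an effect already at smaller amounts and higher numbers for an effect only at larger amounts of compound), gives 33 nM. Compound 2 `O=C(O)c1ccccc1-c1ccc(CCc2ncc(Cc3cccc(Cl)c3)[nH]2)cc1` gives 31 nM and compound 3 `CCCCc1cnc(CCc2ccc(-c3ccccc3C(=O)O)cc2)[nH]1` gives 93 nM. Compound 2 sits at the low end of the three numbers, with compound 1 within the scatter of it (a 1.1-fold lower number from compound 1 to compound 2 (0.03 log units; within the scatter)) and compound 3 beyond it (a 3.0-fold higher number from compound 2 to compound 3 (0.48 log units; beyond the scatter)). Compound 4 `N#Cc1ccccc1Cc1cnc(CCc2ccc(-c3ccccc3C(=O)O)cc2)[nH]1` differs from compound 2 in that (2-cyanophenyl in place of 3-chlorophenyl on a saturated chain carbon bound to an aromatic carbon). Both measured steps at this same place bear on it: 3-chlorophenyl in place of cyclohexylmethyl moved nothing beyond the scatter, while propyl in place of 3-chlorophenyl gave a modest step. Because the earlier move to an aromatic ring at that place gave a 1.1-fold lower number from compound 1 to compound 2 (0.03 log units; within the scatter), compound 4 is expected to keep within the scatter, a 1.3-fold higher number from compound 2 to compound 4 (0.11 log units; within the scatter). Compound 4 is estimated at 40 nM, range 15 nM to 120 nM.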

Compound 4, half-maximal effective concentration: 642 nM
Compound 4: middle estimate off by 16-fold (1.21 log units), on the low side; measured number above the stated range.
By their numbers in this assay, from the lowest: compounds 2 and 1 (each within the scatter of the next); then compound 3; then compound 4.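

At this position an aromatic ring as such does not hold the number: 2-cyanophenyl in place of 3-chlorophenyl gives a 21-fold higher number from compound 2 to compound 4 (1.32 log units; beyond the scatter). The same group also stands behind both saturated groups, with a 19-fold higher number from compound 1 to compound 4 (1.29 log units; beyond the scatter) against cyclohexylmethyl and a 6.9-fold higher number from compound 3 to compound 4 (0.84 log units; beyond the scatter) against propyl. What the ring carries therefore outweighs the choice between ring and chain here.

Still open, from the compounds shown here alone, is whether the nitrile or its place on the ring carries the step, which 3-cyanophenyl and 2-chlorophenyl would separate. Nothing available explains the step.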